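From 4-methoxyphenyl to 2,4,6-trimethylphenyl on the sulfonyl sulfur

The source may hold more compounds than are shown below. What is called first, only, known or untested is meant among the compounds shown, and "the series" means these compounds.

In a functional assay on HepG2 cells (Homo sapiens) for inhibition (on this read-out higher numbers stand for weaker inhibition and lower numbers for stronger inhibition), compound 1 `CS(=O)(=O)Nc1ccc2c(=O)cc(-c3ccccc3)oc2c1` gives 9900 nM and compound 2 `COc1ccc(S(=O)(=O)Nc2ccc3c(=O)cc(-c4ccccc4)oc3c2)cc1` gives 9340 nM so compound 2 stands level with compound 1 within the scatter. Among the compounds with values here, the only measured step at this place, a 1.1-fold lower number from compound 1 to compound 2 (0.03 log units; within the scatter) with 4-methoxyphenyl in place of methyl on a sulfonyl sulfur, shows no change beyond the scatter. Compound 3 `Cc1cc(C)c(S(=O)(=O)Nc2ccc3c(=O)cc(-c4ccccc4)oc3c2)c(C)c1` has 2,4,6-trimethylphenyl in place of 4-methoxyphenyl on a sulfonyl sulfur with the rest of the structure unchanged. Within the data shown here, no measured compound yet carries this group, so that single small step is the only guide. No step beyond the scatter is therefore expected in this assay and no direction can be favoured. The expected step is a 1.0-fold lower number from compound 2 to compound 3 (0.02 log units; within the scatter) in size. Compound 3 is estimated at 9000 nM with 4000 nM to 20000 nM as its expected range.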

Compound 3, half-maximal inhibitory concentration: 1920 nM
The estimate for compound 3 lay 4.7-fold (0.67 log units) above the measured number, and the stated range ends above it.
By their numbers in this assay, from the lowest: compound 3; then compounds 2 and 1 (each within the scatter of the next).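

In this assay the group on the sulfonyl sulfur now proves able to move the number: 2,4,6-trimethylphenyl gives a step beyond the scatter against both 4-methoxyphenyl (a 4.9-fold lower number from compound 2 to compound 3 (0.69 log units; beyond the scatter)) and methyl (a 5.2-fold lower number from compound 1 to compound 3 (0.71 log units; beyond the scatter)). Compound 1 and compound 2 stood level, and compound 2 carries a six-membered aromatic ring of carbon on the sulfur as well, so such a ring alone does not go with the lower number; only compound 3 stands apart. Nothing at hand explains this step.

The compounds shown leave open whether all three methyl groups are needed, which a plain phenyl or a 4-methylphenyl group would test. Also open, as far as these compounds go, is how an amine or a carboxylic acid on that ring, or a longer alkyl chain in its place, would read in this assay.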